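The source may hold more compounds than are shown below. What is called first, only, known or untested is meant among the compounds shown, and "the series" means these compounds.

Working notes on the series. In a functional assay on HeLa cells (Homo sapiens) for inhibition, read by MTT assay, with a stated time of 48 h (a lower number here means a stronger inhibitor, a higher number a weaker inhibitor), compound 3 (`CS(=O)(=O)Nc1ccc(-n2cc(OCc3ccccc3)nn2)cc1Oc1ccccc1`) has no number: its entry reads "not determined" (no result reported) and gives no starting value. The counted difference (4-chlorophenoxy)methyl in place of benzyloxy on an aromatic carbon takes compound 3 to compound 4 (`CS(=O)(=O)Nc1ccc(-n2cc(COc3ccc(Cl)cc3)nn2)cc1Oc1ccccc1`), with (4-chlorophenoxy)methyl in place of benzyloxy on an aromatic carbon. With no number for compound 3, neither size nor direction can be stated for this step. The expectation for compound 4 rests instead on compound 1 (`CS(=O)(=O)Nc1ccc(-n2cc(COc3ccccc3Cl)nn2)cc1Oc1ccccc1`) at 38600 nM and compound 2 (`Cc1ccc(OCc2cn(-c3ccc(NS(C)(=O)=O)c(Oc4ccccc4)c3)nn2)cc1`) at 15800 nM as the nearest measured neighbours, since both carry a substituted phenyl on an oxygen on a saturated carbon, as compound 4 does. Among the compounds with values here, the only measured step is a 2.4-fold lower number from compound 1 to compound 2 (0.39 log units; beyond the scatter) and it is modest, so a chlorine moved within that group is expected to leave compound 4 within the same general span. Compound 4 is estimated at 24000 nM with 9000 nM to 60000 nM as the expected range.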

Compound 4, half-maximal inhibitory concentration: 7800 nM
Compound 4: the middle estimate sits 3.1-fold (0.49 log units) above what was measured, outside the stated range (below it).
By their numbers in this assay, from the lowest: compound 4; then compound 2; then compound 1.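

In this assay, the place of the chlorine within the (4-chlorophenoxy)methyl group makes a difference: a 4.9-fold lower number from compound 1 to compound 4 (0.69 log units; beyond the scatter) comes with a 4-chlorophenyl group taking over from a 2-chlorophenyl group. The halogen-for-alkyl comparison also separates, with a 2.0-fold lower number from compound 2 to compound 4 (0.31 log units; beyond the scatter) for chloro in place of methyl on an aromatic carbon, so compound 4 holds the lowest number of the three measured compounds, with both of its steps beyond the scatter.

The step from compound 3 cannot be read, which leaves the comparison of (4-chlorophenoxy)methyl with benzyloxy at this position unsettled. Also open, from the compounds shown here alone, is how a bromine, a methoxy group, an amine or a carboxylic acid in place of the chlorine would read against compound 4. Nothing on hand accounts for these differences.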